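Swapping a Phenoxy Group for 4-Cyanophenyl: Expected Cytotoxicity

The compounds below may be only part of what the source reports. "The series", "measured", "known", "first", "only" and "open" are said of these compounds alone.

The measured compounds and their values:

Compound 1 `O=C(Nc1cc(-c2ccccn2)n[nH]1)N1CCC(Oc2ccccc2)CC1` gives > 40000 nM in an ADME assay on cells (Peritoneal macrophage cell, Mus musculus) for cytotoxicity, read by fluorescence and resazurin assay, with a stated time of 3 days; a lower number here means that less compound is tolerated, a higher number that more compound is tolerated; this is a limit of the assay, not a number.
Compound 2 `O=C(Nc1[nH]nc(-c2ccccn2)c1C1CC1)c1c(Cl)cccc1Cl` gives > 64000 nM in this assay, again a limit.
Compound 3 `O=C(Nc1cc(-c2ccccn2)n[nH]1)N1CCN(c2ccc(F)cc2)CC1` gives > 57000 nM in this assay, also a limit.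

Compound 1 therefore stands nowhere in particular among the measured numbers: its value is only a limit, as are the other two, as shown by the limit of > 40000 nM in this assay, at which 1 of the 3 values shown sits, the limit of > 57000 nM in this assay, at which 1 of the 3 values shown sits, and (the limit of > 64000 nM in this assay, at which 1 of the 3 values shown sits). In plain terms, none of the three compounds harmed the macrophages at any concentration that was tested, so none can be called more or less tolerated than another. Within the data shown here, no pair of them differs in a single place, so no measured step exists to lean on.

The unmeasured compound 4 `N#Cc1ccc(C2CCN(C(=O)Nc3cc(-c4ccccn4)n[nH]3)CC2)cc1` differs from compound 1 in one place: 4-cyanophenyl in place of phenoxy on a saturated ring carbon.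

In this assay no step beyond the usual scatter is expected, in either direction, for a change of this size on a compound whose value is already a limit, as in compound 1 with > 40000 nM. Compound 4 is expected to give 40000 nM, in the range 15000 nM to 100000 nM, most likely reported again as a limit, so that the estimated step of a number no higher from compound 1 to compound 4 (the limit leaves the size open) is essentially none.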

Compound 4, half-maximal cytotoxic concentration: > 64000 nM
Compound 4 ended at the assay's limit (the forecaster's own chance of this, stated with the estimate: 80%); middle value at least 1.6-fold (0.20 log units) away from the limit.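

In this assay compound 4 gives > 64000 nM, which is a limit of the assay and not a number. Among these compounds, compound 1 also carries only a limit, so no step from compound 1 to compound 4 can be read. The compounds shown leave open what concentration would harm the macrophages, and whether 4-cyanophenyl in place of phenoxy changes tolerance at all.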